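A few compounds are considered here, and "the series" means these few. Any claim that something is new, unique, unknown or untested is made for them only; others in the source may bear on it.

In a functional assay on the whole organism (strain Wistar) for inhibition, with Rattus norvegicus as the target, read by paw edema, with stated times of 30 min and 5 h, at a dose of 5 mg/kg by the oral route (a lower number here means a weaker effect, a higher number a stronger effect of the compound at the dose given), compound 1 `CCOc1cc(C(C)=O)ccc1NS(C)(=O)=O` gives 44%, and compound 2 `CCCOc1cc(C(C)=O)ccc1NS(C)(=O)=O` gives 56.6%. Among the compounds with values here, the single measured step between them is a number 12.6 percentage points higher from compound 1 to compound 2 (beyond the scatter). Compound 2 therefore stands highest of the two numbers, with compound 1 the nearest value, a number below it beyond the scatter. Compound 3 `CC(=O)c1ccc(NS(C)(=O)=O)c(OC2CCCC2)c1` has not yet been measured in this assay. It differs from compound 2 by cyclopentyl in place of propyl on an oxygen on an aromatic ring. Within the data shown here, the only step that bears on this change is a number 12.6 percentage points higher from compound 1 to compound 2 (beyond the scatter), which gave a modest rise when the group on the oxygen on the aromatic ring was enlarged; no measured step shows a ring in this place, so the expectation rests on that one step alone. The step of a number 5.4 percentage points higher from compound 2 to compound 3 (within the scatter) is expected to be small and upward, if anything. For compound 3 the estimate in this assay is 62%, with a range from 45% to 78%.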

Compound 3, a percentage reported as inhibition, in the whole organism at one dose (the size of the read-out at that dose, not a potency): 58.7%
Compound 3: the middle estimate sits 3.3 percentage points above what was measured; low and high end bracket the measured number.
By their numbers in this assay, from the lowest: compound 1; then compounds 2 and 3 (each within the scatter of the next).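

In this assay the group on the oxygen on an aromatic ring need not be an open chain: cyclopentyl in place of propyl gives a number 2.1 percentage points higher from compound 2 to compound 3 (within the scatter) and so leaves compounds 2 and 3 indistinguishable, showing that a five-membered ring is accepted here. Cyclopentyl in place of ethyl gives a number 14.7 percentage points higher from compound 1 to compound 3 (beyond the scatter) and thus lies beyond the scatter, as does the printed step from ethyl to propyl, so both larger groups stand apart from the ethyl of compound 1. Nothing available explains this result.

Going by these compounds, whether a longer chain such as butyl or a larger ring such as cyclohexyl on this oxygen would match compounds 2 and 3 remains open. So does the effect of an amine or a carboxylic acid carried on that group.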